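This account rests on a few compounds, and the source may have more. Where it says the series, first, only, none or still open, it means among the compounds named here.

Measured in a physicochemical assay for lipophilicity, at pH 7.4 (on this read-out higher numbers stand for higher lipophilicity and lower numbers for lower lipophilicity), both values being limits:
Compound 1 `Cc1cc(C(=O)Nc2ccccc2)nn1Cc1cc(Cl)ccc1OCc1ccccc1`: > 3.7
Compound 2 `Cc1cc(C(=O)NCc2ccncc2)nn1Cc1cc(Cl)ccc1OCc1ccccc1`: > 3.7

In this assay, compound 2 stands only at a limit, > 3.7, and that limit is the sole anchor for what follows. The data offer no more than the limit of > 3.7 in this assay, at which 2 of the 2 values shown sit. Compound 3 `Cc1cc(NC(=O)C(C)C)nn1Cc1cc(Cl)ccc1OCc1ccccc1` brings ((isopropylcarbonyl)amino in place of ((pyridin-4-yl)methyl)carbamoyl on an aromatic carbon). Among the measured compounds shown here, the only measured step is a step that the two limits leave unreadable from compound 1 to compound 2, so no size or direction can be carried over from it. No step beyond the scatter is therefore assumed, and the expected step that the limit leaves unreadable from compound 2 to compound 3 is only a rough estimate. For compound 3 the estimated value is 3.9, expected between 3.3 and 4.5.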

Compound 3, distribution coefficient: > 3.7
Compound 3: no number, only a limit; the forecaster's own chance of this, stated with the estimate: 65%; the middle value does not contradict the limit.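

In this assay, among the compounds shown here, compound 3 gives > 3.7 as a limit, so no step to it from compound 1 or compound 2 can be read. The compounds shown leave open how the actual values of all three compare.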